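Adding a Bromine Atom to a Compound at the Assay Limit

A few compounds are considered here, and "the series" means these few. Any claim that something is new, unique, unknown or untested is made for them only; others in the source may bear on it.

Compound 1 `Nc1nc2c(Cl)cc(Cl)cc2n1COCCO`: > 100000 nM
Compound 2 `OCCOCn1cnc2c(Cl)cc(Cl)cc21`: > 100000 nM

In a functional assay on KB cells (Homo sapiens) for inhibition (a higher number here means a weaker inhibitor, a lower number a stronger inhibitor), compound 1 gives > 100000 nM, which is a limit of the assay rather than a measured number. In this assay compound 2 gives > 100000 nM, again a limit and not a number. Among the measured compounds shown here, the single measured step, a step that the two limits leave unreadable from compound 1 to compound 2, is therefore unreadable in size and direction. Compound 2 stands at the limit of > 100000 nM in this assay, at which 2 of the 2 values shown sit, so its true potency is known only to be weak.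

Compound 3 `OCCOCn1c(Br)nc2c(Cl)cc(Cl)cc21` differs from compound 2 by bromo in place of hydrogen on an aromatic carbon. For the measured compounds named here, no measured step with a readable size bears on this change, so the numbers give no direction for it. Compound 3 is expected to give about 100000 nM in this assay, with a range from 30000 nM to 300000 nM, and most probably only a limit again. The expected step of a number no higher from compound 2 to compound 3 (the limit leaves the size open) is thus estimated to be none beyond the scatter.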

Compound 3, half-maximal inhibitory concentration: > 100000 nM
Compound 3: a limit, no number (the forecaster's own chance of this, stated with the estimate: 85%); the middle value sits exactly at the limit.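

In this assay, among the compounds shown here, compound 3 gives > 100000 nM, again a limit and not a number, so no step among compound 1, compound 2 and compound 3 can be read. The compounds shown leave open whether amino, hydrogen or bromo on that carbon changes potency at all, since all three share one result: the limit of > 100000 nM in this assay, at which 3 of the 3 values shown sit.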